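Trifluoromethyl in Place of Amino on a Shared Core

A few compounds are considered here, and "the series" means these few. Any claim that something is new, unique, unknown or untested is made for them only; others in the source may bear on it.

Compound 2 `CC1(C)CN(C2=CCCC2=O)c2cc(N)ccc2S1` gives 96% in a functional assay on aorta (Rattus norvegicus, strain Wistar) (on this read-out higher numbers stand for larger maximal responses and lower numbers for smaller maximal responses), the highest of three numbers, though compound 3 `CC1(C)CSc2ccc(C(F)(F)F)cc2N1C1=CCCC1=O` with 89% and compound 1 `CC(=O)c1ccc2c(c1)N(C1=CCCC1=O)CC(C)(C)S2` with 88% both lie within the scatter of it. Compound 4 `CC1(C)CN(C2=CCCC2=O)c2cc(C(F)(F)F)ccc2S1` differs from compound 2 by trifluoromethyl in place of amino on an aromatic carbon. For the measured compounds named here, the only measured step at this place, a number 8 percentage points higher from compound 1 to compound 2 (within the scatter), stayed within the scatter, and compound 3, which also carries a trifluoromethyl, shows a number close to compound 2. For compound 4 no change beyond the scatter is therefore expected, and the estimated step is a number 6 percentage points lower from compound 2 to compound 4 (within the scatter). Compound 4 is expected to reach about 90%, within a range of 80% to 98%.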

Compound 4, largest response reached (Emax), in percent of the reference or control that the assay uses: 92%
The estimate for compound 4 lay 2 percentage points below the measured number; the range from low to high includes it.
By their numbers in this assay, from the lowest: compounds 1, 3, 4 and 2 (each within the scatter of the next).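

In this assay, this position on the shared core now holds amino, acetyl and trifluoromethyl, and neither new step leaves the scatter (a number 4 percentage points lower from compound 2 to compound 4 (within the scatter)) (a number 4 percentage points higher from compound 1 to compound 4 (within the scatter)). Replacing amino with trifluoromethyl removes a hydrogen-bond donor and a hydrogen-bond acceptor from this aromatic carbon, yet the maximal response does not change measurably. Nothing available explains this result. A carboxylic acid or a longer alkyl chain at this position remains untested among the compounds shown, so the limits of this tolerance stay open.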